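This account rests on a few compounds, and the source may have more. Where it says the series, first, only, none or still open, it means among the compounds named here.

Compound 1, `Cc1cnc(Nc2ccc(C(C)C)cc2)nc1Nc1nc2ccccc2s1`, in a functional assay on MCF7 cells (Homo sapiens) for antiproliferative activity, read by MTT assay, with a stated time of 48 h (a higher number here means a weaker inhibitor, a lower number a stronger inhibitor), gives > 50000 nM, which is a limit of the assay.
Compound 2, `Cc1cnc(Nc2ccc(S(N)(=O)=O)cc2)nc1Nc1nc2ccccc2s1`, in this assay gives > 50000 nM, again a limit.
Compound 3, `COc1ccc2nc(Nc3nc(Nc4ccc(S(N)(=O)=O)cc4)ncc3C)sc2c1`, in this assay gives > 50000 nM, once more a limit.

Compound 2 therefore stands at the limit of this assay, the same place at which every measured value of this series sits (the limit of > 50000 nM in this assay, at which 3 of the 3 values shown sit). The two measured steps touching it, a step that the two limits leave unreadable from compound 1 to compound 2 and a step that the two limits leave unreadable from compound 2 to compound 3, run between limits and give no readable size.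

Compound 4, `NS(=O)(=O)c1ccc(Nc2nccc(Nc3nc4ccccc4s3)n2)cc1`, differs from compound 2 by hydrogen in place of methyl on an aromatic carbon. Among the measured compounds shown here, no measured step concerns the methyl group, and no measured step has a readable size, so nothing in the data points to a change beyond the scatter in either direction. The step from compound 2 to compound 4 in this assay is accordingly expected to be a step that the limit leaves unreadable from compound 2 to compound 4, with a fair chance that compound 4 also returns only a limit. For compound 4 in this assay the estimate is 60000 nM, within 10000 nM to 200000 nM.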

Compound 4, half-maximal inhibitory concentration: 15300 nM
Compound 4: the middle estimate sits 3.9-fold (0.59 log units) above what was measured; measured number inside the range.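

In this assay, among the compounds shown here, hydrogen in place of methyl on this aromatic carbon of the six-membered aromatic ring with 2 nitrogen gives an at least 3.2-fold lower number from compound 2 to compound 4 (0.51 log units; beyond the scatter), the first step with a readable size, as the earlier steps run between limits and cannot be read. Compound 2 holds only a limit, so the true size of this step may be larger than the printed one. The series therefore responds to a change at this carbon, and compound 4 alone stands off the limit: the limit of > 50000 nM in this assay, at which 3 of the 4 values shown sit.

Going by these compounds, whether a fluorine, an amine or an ethyl group at this carbon would also leave the limit stays open. Also open, on these data alone, is whether the isopropyl and methoxy changes, unreadable with the methyl present, would have a readable effect with hydrogen at this carbon.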